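The source may hold more compounds than are shown below. What is called first, only, known or untested is meant among the compounds shown, and "the series" means these compounds.

Compound 1 `COc1ccc(-c2nc(C)c(C(=O)CSc3nc(-c4ccc(Cl)cc4)c(C#N)c(=O)[nH]3)s2)cc1`: 2.85%
Compound 2 `COc1ccc(-c2nc(C)c(C(=O)CSc3nc(-c4ccc(OC)cc4)c(C#N)c(=O)[nH]3)s2)cc1`: 11.5%
Compound 3 `COc1ccc(-c2nc(C)c(C(=O)CSc3nc(-c4ccc(Cl)c(Cl)c4)c(C#N)c(=O)[nH]3)s2)cc1`: 31.1%

Of the compounds shown here, three built on one shared core have been tested in a functional assay on U-87MG ATCC cells for antiproliferative activity against U-87 MG (Homo sapiens), read by MTT assay, with a stated time of 48 h, tested at 100 uM; on this read-out lower numbers stand for a stronger effect and higher numbers for a weaker effect at the one concentration tested. Compound 3 stands highest of the three numbers there, meaning the weakest effect: the step to it from compound 2 is a number 19.6 percentage points higher from compound 2 to compound 3 (beyond the scatter), and the step to it from compound 1 is a number 28.3 percentage points higher from compound 1 to compound 3 (beyond the scatter), both beyond the scatter. Compound 4 `COc1ccc(-c2nc(C)c(C(=O)CSc3nc(-c4cccc(Cl)c4)c(C#N)c(=O)[nH]3)s2)cc1` has not yet been measured. It differs from compound 3 in one place: hydrogen in place of chloro on an aromatic carbon.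

The measured step that bears most on this change is the one in which a chloro entered, a number 28.3 percentage points higher from compound 1 to compound 3 (beyond the scatter), which raised the number modestly. Compound 4 removes a chloro again, though not the same one, so the change partly undoes that step; the step of a number 8.7 percentage points higher from compound 1 to compound 2 (within the scatter), within the scatter, shows that small changes on this ring can also leave the number unmoved. A modest move downward is therefore expected, with wide uncertainty. Compound 4 is estimated to give about 15%, between 3% and 33%. This amounts to an expected step of a number 16.1 percentage points lower from compound 3 to compound 4 (beyond the scatter).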

Compound 4, a percentage reported as activity, at one concentration (the size of the read-out at that concentration, not a potency): 40.6%
Beside the measured number, compound 4's estimate is 25.6 percentage points below it; measured number outside the range, above it.
By their numbers in this assay, from the lowest: compounds 1 and 2 (each within the scatter of the next); then compounds 3 and 4 (each within the scatter of the next).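

In this assay, going from 3,4-dichlorophenyl to 3-chlorophenyl gives a number 9.5 percentage points higher from compound 3 to compound 4 (within the scatter) so the chloro para to a large group can be lost with no change that stands out from the scatter. What separates these compounds is instead where the substituent sits on the ring: a number 37.8 percentage points higher from compound 1 to compound 4 (beyond the scatter) is a large weakening when 3-chlorophenyl replaces 4-chlorophenyl, and a number 29.1 percentage points higher from compound 2 to compound 4 (beyond the scatter) is a modest one when it replaces 4-methoxyphenyl. Among these four compounds, the two carrying a chloro at that remaining ring place, compound 3 and compound 4, both show weaker effects than compound 1 and compound 2, and none goes against this.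

As far as these compounds go, whether an amine or a carboxylic acid in place of the new hydrogen would bring back a stronger effect stays open. Nothing measured here gives a reason for these differences.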